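This account rests on a few compounds, and the source may have more. Where it says the series, first, only, none or still open, it means among the compounds named here.

Measured compounds in an in vitro functional assay on cells for agonist activity at Bombesin receptor subtype-3 (Homo sapiens), read by luminescence and calcium flux; a higher number here means that more compound is needed for the effect, a lower number that less compound is needed:
compound 1 `Cc1cccc(Cc2cnc(CCc3ccc(-c4ccccc4C(=O)O)cc3)[nH]2)c1` gives 4310 nM;
compound 2 `O=C(O)c1ccccc1-c1ccc(CCc2ncc(Cc3cccc(F)c3)[nH]2)cc1` gives 159 nM;
compound 3 `O=C(O)c1ccccc1-c1ccc(CCc2ncc(CCc3ccccc3)[nH]2)cc1` gives 1320 nM.

Compound 3 stands second highest of the three, with compound 1 nearest and compound 2 furthest. Compound 4 `CCC(C)(CC)Cc1cnc(CCc2ccc(-c3ccccc3C(=O)O)cc2)[nH]1` differs from compound 3 by 1-ethyl-1-methylpropyl in place of benzyl on a saturated chain carbon bound to an aromatic carbon. The measured steps at this position, a 3.3-fold lower number from compound 1 to compound 3 (0.51 log units; beyond the scatter) and an 8.3-fold higher number from compound 2 to compound 3 (0.92 log units; beyond the scatter), concern changes of the aromatic group itself, none of them removes the ring, so they bear only loosely on this change. The account therefore expects a step in this assay that is small and most likely toward a higher number, a 1.9-fold higher number from compound 3 to compound 4 (0.28 log units; within the scatter). Compound 4 is estimated at 2500 nM, within a range from 600 nM to 10000 nM.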

Compound 4, half-maximal effective concentration: 76 nM
Compound 4: the middle estimate sits 33-fold (1.52 log units) above what was measured, outside the stated range (below it).
By their numbers in this assay, from the lowest: compound 4; then compound 2; then compound 3; then compound 1.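

In this assay, the group on the saturated chain carbon bound to an aromatic carbon proves not to need a ring: with 1-ethyl-1-methylpropyl in place of benzyl there is a 17-fold lower number from compound 3 to compound 4 (1.24 log units; beyond the scatter) and, against the 3-methylphenyl group, a 57-fold lower number from compound 1 to compound 4 (1.75 log units; beyond the scatter) in the same direction. The branched chain also edges past the 3-fluorophenyl group, with a 2.1-fold lower number from compound 2 to compound 4 (0.32 log units; beyond the scatter) beyond the scatter. No evidence at hand accounts for this result. The compounds shown leave open whether a shorter branched chain such as isopropyl, or a branched chain carrying a hydroxyl or an amine, would keep so low a number.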